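Methoxy in Place of Tert-Butyl on the Shared Core

This account rests on a few compounds, and the source may have more. Where it says the series, first, only, none or still open, it means among the compounds named here.

Measured so far in a functional assay on B16-F0 cells (Mus musculus) for inhibition, read by CCK-8 assay, with a stated time of 48 h; a higher number here means a weaker inhibitor, a lower number a stronger inhibitor:
Compound 1, `COc1cc(-c2ccnc3cc(-c4ccc(C(C)(C)C)cc4)nn23)cc(OC)c1OC`, sits at the limit > 10000 nM.
Compound 2, `Cc1ccc(-c2cc3nccc(-c4ccc(F)cc4)n3n2)cc1`, sits at the limit > 10000 nM.
Compound 3, `COc1cc(-c2ccnc3cc(-c4ccc(N(C)C)cc4)nn23)cc(OC)c1OC`, gives 702 nM.

Compound 1 stands at the limit of > 10000 nM in this assay, at which 2 of the 3 values shown sit, so its value is a limit and not a number. Only compound 3 gives a number. The step from compound 1 to compound 3 exchanged tert-butyl for dimethylamino on the same aromatic carbon and gave an at least 14-fold lower number from compound 1 to compound 3 (1.15 log units; beyond the scatter), a large move out of the limit. Compound 4, `COc1ccc(-c2cc3nccc(-c4cc(OC)c(OC)c(OC)c4)n3n2)cc1`, differs from compound 1 as follows: methoxy in place of tert-butyl on an aromatic carbon. Within the data shown here, the only measured step that bears on this is the one to compound 3, which replaced the same tert-butyl at the same place and was large. Methoxy is a different group from dimethylamino, and no measured step shows what methoxy alone does at this place. The expectation for compound 4 is a step in the same direction but of uncertain size, namely an at least 3.3-fold lower number from compound 1 to compound 4 (0.52 log units; beyond the scatter). Compound 4 is therefore estimated at 3000 nM, with a range from 700 nM to 10000 nM.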

Compound 4, half-maximal inhibitory concentration: 1410 nM
For compound 4 the middle estimate is 2.1-fold (0.33 log units) above the measured one; the measured number falls inside the stated range.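

Methoxy in place of tert-butyl, on the aromatic carbon para to a large group, gives an at least 7.0-fold lower number from compound 1 to compound 4 (0.85 log units; beyond the scatter), so leaving the limit at this place does not depend on dimethylamino alone. The two replacements are not separated in this assay: the comparison gives a 2.0-fold higher number from compound 3 to compound 4 (0.30 log units; within the scatter), and no order between methoxy and dimethylamino can be read from it. Compound 1 remains a limit and not a number, so the true size of its step stays unknown: the limit of > 10000 nM in this assay, at which 2 of the 4 values shown sit.

Still open, going by these compounds, is whether any group in place of tert-butyl would serve, or whether the change depends on the attached group, as a hydroxyl, a primary amine or a chlorine at this place could show. Compound 2 differs from the others in more than one place, so it does not show whether the step carries over to other substitution on the shared core.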